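This account rests on a few compounds, and the source may have more. Where it says the series, first, only, none or still open, it means among the compounds named here.

Compound 1 `COc1cc(OCc2cnc(Cl)c(Cl)c2)ccc1CNCc1ccncc1` gives 400 nM
Compound 2 `COc1cc(CNCc2ccncc2)ccc1OCc1ccc(C)cc1` gives 5000 nM

In a functional assay on HeLa cells (Homo sapiens) for inhibition, with a stated time of 72 h (a higher number here means that more compound is needed for the effect, a lower number that less compound is needed), compound 2 stands highest of the two at 5000 nM and compound 1 gives 400 nM as the lower number, a gap beyond the scatter. Compound 3 `COc1cc(CNCc2ccncc2)ccc1OCc1ccc(Cl)cc1Cl` has 2,4-dichlorophenyl in place of 4-methylphenyl on a saturated chain carbon bound to an oxygen on an aromatic ring in its difference from compound 2. Within the data shown here, no measured pair isolates this change. Compound 1 also carries chlorine and gives 400 nM in this assay so a moderate fall is expected, the estimated 3.3-fold lower number from compound 2 to compound 3 (0.52 log units; beyond the scatter) in this direction. For compound 3 the estimated value is 1500 nM with an expected range from 400 nM to 5000 nM in this assay.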

Compound 3, half-maximal effective concentration: 3900 nM
Beside the measured number, compound 3's estimate is 2.6-fold (0.41 log units) below it; low and high end bracket the measured number.
By their numbers in this assay, from the lowest: compound 1; then compounds 3 and 2 (each within the scatter of the next).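

In this assay, 2,4-dichlorophenyl in place of 4-methylphenyl on a saturated chain carbon bound to an oxygen on an aromatic ring gives a 1.3-fold lower number from compound 2 to compound 3 (0.11 log units; within the scatter) and so does not separate the two compounds. Among these compounds, this is the first pair here that differs in one place, and it shows that this exchange alone leaves the read-out within the scatter. Nothing measured here bears on this result. Still open, as far as these compounds go, is whether a carboxylic acid or a morpholine in place of 2,4-dichlorophenyl would give a number beyond the scatter from compound 2.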